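The source may hold more compounds than are shown below. What is called first, only, known or untested is meant among the compounds shown, and "the series" means these compounds.

Compound 1 `COc1cc2cc(Oc3ccc(NC(=O)Nc4cccc(C(F)(F)F)c4)cc3)c(C)nc2cc1OC` gives 32000 nM in a functional assay on SR cells (Homo sapiens) for inhibition, read by sulforhodamine B assay, with a stated time of 48 h; on this read-out higher numbers stand for lower toxicity in this test and lower numbers for higher toxicity in this test.
Compound 2 `COc1cc2cc(Oc3ccc(NC(=O)Nc4ccc(Cl)c(C(F)(F)F)c4)cc3)c(C)nc2cc1OC` reaches only a limit of > 32500 nM in this assay, an assay boundary rather than a number.

Compound 2 therefore stands at the upper edge of what this assay can report, as a limit (the limit of > 32500 nM in this assay, at which 1 of the 2 values shown sits). The change to compound 3 `COc1cc2cc(Oc3ccc(NC(=O)Nc4ccc(Cl)c(Cl)c4)cc3)c(C)nc2cc1OC` is chloro in place of trifluoromethyl on an aromatic carbon. Going by the values given here, the only measured step, an at least 1.0-fold higher number from compound 1 to compound 2 (0.00 log units; that floor lies within the scatter), stayed within the scatter, and no measured step swaps trifluoromethyl for chloro. No shift beyond the scatter is expected in this assay. Compound 3 is thus estimated at 30000 nM, between 10000 nM and 32500 nM, an expected step of an at least 1.0-fold lower number from compound 2 to compound 3 (0.03 log units; that floor lies within the scatter).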

Compound 3, concentration lethal to 50% of the cells: > 100000 nM
Compound 3: only a limit was reported (the forecaster's own chance of this, stated with the estimate: 50%); middle value at least 3.3-fold (0.52 log units) from the limit.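

In this assay compound 3 gives > 100000 nM, which is a limit of the assay and not a number. With chloro in place of trifluoromethyl on this carbon, the read-out is again a limit, so the step between the two chlorinated compounds cannot be read. The 3,4-dichlorophenyl group in place of 3-(trifluoromethyl)phenyl gives the first shift beyond the scatter, toward lower toxicity in this test: an at least 3.1-fold higher number from compound 1 to compound 3 (0.49 log units; beyond the scatter).

Going by these compounds, the true numbers behind both limits stay open, and so does which of trifluoromethyl and chloro gives the higher one. On these data alone, how an amine or a nitrile on this carbon would read also stays open.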